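The compounds below may be only part of what the source reports. "The series", "measured", "known", "first", "only" and "open" are said of these compounds alone.

Compound 1 `Nc1nc(N2CCCC2)c2ncn(/C=C3/CC3(CO)CO)c2n1` carries in an ADME assay on MOLT-3 cells (Homo sapiens) for cytotoxicity, with a stated time of 7 days (a lower number here means that less compound is tolerated, a higher number that more compound is tolerated), only the entry "not determined" (no result reported), so no single number marks where it stands. Compound 2 `Nc1nc2c(ncn2/C=C2/CC2(CO)CO)c(=O)[nH]1` reaches in this assay only > 20000 nM, which is a limit of the assay and not a number. That is the limit of > 20000 nM in this assay, at which 1 of the 2 values shown sits. Compound 3 `CNc1nc(N)nc2c1ncn2/C=C1/CC1(CO)CO` differs from compound 1 by methylamino in place of pyrrolidin-1-yl on an aromatic carbon. With no number for compound 1 in this assay, no step size can be drawn from measurement; any shift is expected to stay within the scatter. Compound 3 is therefore expected to give about 20000 nM, between 10000 nM and 50000 nM.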

Compound 3, half-maximal cytotoxic concentration: > 20000 nM
Compound 3 gave a limit, no number; the forecaster's own chance of this, stated with the estimate: 80%; the middle value sits exactly at the limit.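

In this assay compound 3 gives > 20000 nM, which is a limit and not a number. Among the compounds shown here, no step from compound 1 to compound 3 can be read from this. The compounds shown leave open whether methylamino in place of pyrrolidin-1-yl changes this read-out at all.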